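A few compounds are considered here, and "the series" means these few. Any claim that something is new, unique, unknown or untested is made for them only; others in the source may bear on it.

Three compounds built on a shared core have been examined in a functional assay on B16-F10 cells (Mus musculus) for cytotoxicity, read by MTT assay, with a stated time of 48 h; on this read-out lower numbers stand for stronger inhibition and higher numbers for weaker inhibition. Compound 1 `Cc1ccc2nc(Nc3nc4ccccc4s3)sc2c1` reaches only the limit of the assay, > 50000 nM, in this assay. Compound 3 `Fc1ccc(NC(=S)Nc2nc3ccccc3s2)cc1` likewise returns only a limit, > 50000 nM, in this assay. Within the data shown here, compound 2 `CCOc1ccc2nc(Nc3nc4ccc(F)cc4s3)sc2c1` is the one compound with a number: in this assay compound 2 gives 33200 nM. It therefore stands alone among the values shown, the other two being limits (the limit of > 50000 nM in this assay, at which 2 of the 3 values shown sit).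

Compound 4 `Cc1ccc2nc(Nc3nc4ccc(F)cc4s3)sc2c1` has not yet been measured in this assay. It differs from compound 2 in one place, (methyl in place of ethoxy on an aromatic carbon), methyl in place of ethoxy on an aromatic carbon. Among the measured compounds shown here, no measured step of this kind exists among the three compounds, so the size of the change can only be anticipated; compound 2 itself gives 33200 nM in this assay. Compound 4 is expected to give about 45000 nM, within 20000 nM to 100000 nM, in this assay. The estimated step is a 1.4-fold higher number from compound 2 to compound 4 (0.13 log units; within the scatter), toward weaker inhibition if anything, with a fair chance that only a limit is reported.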

Compound 4, half-maximal inhibitory concentration: 29600 nM
Compound 4: the middle estimate sits 1.5-fold (0.18 log units) above what was measured, within the range that was stated.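

In this assay, methyl in place of ethoxy on this aromatic carbon gives a 1.1-fold lower number from compound 2 to compound 4 (0.05 log units; within the scatter), so the exchange leaves the number at this position indistinguishable from that of compound 2. Fluoro in place of hydrogen on an aromatic carbon gives an at least 1.6-fold lower number from compound 1 to compound 4 (0.22 log units; that floor lies within the scatter), a step that rests on a limit and can be read only as a floor. Compound 1 therefore remains a limit and not a number, which restricts what this second step can show: the limit of > 50000 nM in this assay, at which 2 of the 4 values shown sit.

The compounds shown leave open whether an amine, a carboxylic acid or a longer chain on this aromatic carbon would move the number beyond the scatter. They also leave open how large the fluoro step really is, as only its floor can be read.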